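Benzimidazole-methyl piperazine amides: ring substituent swap toward compound 3

A few compounds are considered here, and "the series" means these few. Any claim that something is new, unique, unknown or untested is made for them only; others in the source may bear on it.

Measured so far:
- compound 1, `O=C(C1CC1)N1CCN(Cc2nc3ccccc3n2Cc2ccccc2C(F)(F)F)CC1`, an assay on isolated protein for inhibition of aldehyde dehydrogenase 1A1 (Homo sapiens), read by spectrophotometry, tested at 10 uM; a higher number here means more inhibition at the concentration tested (going by the name of the read-out), a lower number less inhibition: 56.3%
- compound 2, `O=C(C1CC1)N1CCN(Cc2nc3ccccc3n2Cc2ccc(C(F)(F)F)cc2)CC1`, this assay: 37%

Compound 2 stands lowest of the two numbers in this assay; its nearest neighbour is compound 1, and the step of a number 19.3 percentage points lower from compound 1 to compound 2 (beyond the scatter) lies beyond the scatter. Compound 3, `Cc1ccccc1Cn1c(CN2CCN(C(=O)C3CC3)CC2)nc2ccccc21`, is not yet measured. Its change from compound 2 is 2-methylphenyl in place of 4-(trifluoromethyl)phenyl on a saturated chain carbon bound to an aromatic nitrogen.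

Among the compounds with values here, only one measured step bears on this change: the move from compound 1 to compound 2 exchanged 2-(trifluoromethyl)phenyl for 4-(trifluoromethyl)phenyl and cost a number 19.3 percentage points lower from compound 1 to compound 2 (beyond the scatter). Compound 3 returns to a substituent at the 2-position of the phenyl, though with methyl rather than trifluoromethyl, for which no comparison exists. The expected step is therefore upward, roughly a number 13 percentage points higher from compound 2 to compound 3 (beyond the scatter), but with wide uncertainty. Compound 3 is estimated at 50%, range 30% to 70%.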

Compound 3, a percentage reported as inhibition, at one concentration (the size of the read-out at that concentration, not a potency): 29.1%
The estimate for compound 3 lay 20.9 percentage points above the measured number; measured number below the stated range.
By their numbers in this assay, from the lowest: compounds 3 and 2 (each within the scatter of the next); then compound 1.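

In this assay, methyl in place of trifluoromethyl on an aromatic carbon gives a number 27.2 percentage points lower from compound 1 to compound 3 (beyond the scatter), so the higher number of compound 1 does not carry over to 2-methylphenyl and, within these compounds, goes with 2-(trifluoromethyl)phenyl specifically. With 2-methylphenyl in place of 4-(trifluoromethyl)phenyl on a saturated chain carbon bound to an aromatic nitrogen, the result is a number 7.9 percentage points lower from compound 2 to compound 3 (within the scatter), so compound 2 and compound 3 cannot be told apart here, and only compound 1 stands clear of the other two. No evidence is available to explain this difference between methyl and trifluoromethyl.

Still open, as far as these compounds go, is whether a chlorine atom or a methoxy group on that same aromatic carbon would stay with compound 1 or with compound 3. Also open, from the compounds shown here alone, is whether any such result would hold with a different acyl group on the piperazine, such as acetyl.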